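The source may report more compounds than this note shows. Statements on the series, on what has been measured and on what is new or still open speak of the compounds shown alone.

In an assay on cells for inhibition of Amine oxidase [flavin-containing] B (Homo sapiens), read by Amplex Red, with stated times of 30 min and 45 min (on this read-out higher numbers stand for weaker inhibition and lower numbers for stronger inhibition), compound 1 `C#CCCCOc1ccc2oc(=O)c(C(=O)OC)cc2c1` gives 1440 nM, the only number shown in this set. Compound 2 `C#CCCCOc1ccc2cc(C(=O)O)c(=O)oc2c1` returns a limit of the assay, > 10000 nM. Compound 3 `C#CCCCCOc1ccc2oc(=O)c(C(=O)c3ccc(OC)cc3)cc2c1` likewise returns a limit, > 10000 nM. Within the data shown here, two of the three values thus sit at the limit of > 10000 nM in this assay, at which 2 of the 3 values shown sit, and no pair of measured compounds differs in a single place, so no measured step is available. Compound 4 `COC(=O)c1cc2cc(OCc3cccc(Cl)c3)ccc2oc1=O` has not yet been measured; it differs from compound 1 by 3-chlorophenyl in place of but-3-yn-1-yl on a saturated chain carbon bound to an oxygen on an aromatic ring. In this assay a modest step toward stronger inhibition, near the edge of the usual scatter, is expected. For compound 4 the expected value is 600 nM, with a range from 100 nM to 4000 nM, meaning an expected step of a 2.4-fold lower number from compound 1 to compound 4 (0.38 log units; beyond the scatter).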

Compound 4, half-maximal inhibitory concentration: 31.5 nM
Compound 4: the middle estimate sits 19-fold (1.28 log units) above what was measured, outside the stated range (below it).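

In this assay, 3-chlorobenzyl in place of pent-4-yn-1-yl gives a 46-fold lower number from compound 1 to compound 4 (1.66 log units; beyond the scatter), so this place on the shared core can carry a large change in inhibition. The triple bond is not needed for strong inhibition in this pair. Only compound 1 and compound 4 give numbers, and the remaining values are limits: the limit of > 10000 nM in this assay, at which 2 of the 4 values shown sit.

On these data alone, whether the step comes from the aromatic ring or the chlorine stays open, since an unsubstituted benzyl would separate the two. Also open, as far as these compounds go, is whether it holds with an amide in place of the ester.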